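This account rests on a few compounds, and the source may have more. Where it says the series, first, only, none or still open, it means among the compounds named here.

Measured so far:
- compound 1, `CCOC(=O)C1=Cc2ccccc2OC1(OCc1cn(-c2ccc(F)cc2)nn1)C(F)(F)F`: 9100 nM
- compound 2, `CCOC(=O)C1=Cc2ccccc2OC1(OCc1cn(CC(=O)Nc2ccc(OC)cc2)nn1)C(F)(F)F`: 28100 nM

Both numbers come from a functional assay on MCF7 cells (Homo sapiens) for inhibition, read by MTT assay, with a stated time of 24 h; a lower number here means a stronger inhibitor, a higher number a weaker inhibitor. Compound 2 stands as the higher of the two: from compound 1 to compound 2 the step was a 3.1-fold higher number from compound 1 to compound 2 (0.49 log units; beyond the scatter), so compound 2 is the weaker inhibitor in this pair.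

Compound 3, `CCOC(=O)C1=Cc2ccccc2OC1(OCc1cn(CC(=O)Nc2ccccc2Br)nn1)C(F)(F)F`, has not been measured. It differs from compound 2 in one place: 2-bromophenyl in place of 4-methoxyphenyl on an amide-type nitrogen. Among the compounds with values here, the only measured step, a 3.1-fold higher number from compound 1 to compound 2 (0.49 log units; beyond the scatter), concerns a different part of the molecule, the group on the aromatic nitrogen, and so does not bear directly on an exchange made on the amide-type nitrogen. With nothing measured for this kind of exchange, the expectation is a step within the scatter, in no firm direction, estimated as a 1.1-fold lower number from compound 2 to compound 3 (0.05 log units; within the scatter). Compound 3 is therefore expected to give about 25000 nM in this assay, with a range from 8000 nM to 80000 nM.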

Compound 3, half-maximal inhibitory concentration: > 150000 nM
Compound 3: a limit, no number (the forecaster's own chance of this, stated with the estimate: 15%); at least 6.0-fold (0.77 log units) between middle value and limit.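

The group on the amide-type nitrogen, which compounds 1 and 2 did not address, clearly matters: 2-bromophenyl in place of 4-methoxyphenyl gives an at least 5.3-fold higher number from compound 2 to compound 3 (0.72 log units; beyond the scatter). In this assay compound 3 gives a limit of the assay and not a number: the limit of > 150000 nM in this assay, at which 1 of the 3 values shown sits. Replacing the whole 4-fluorophenyl group on the aromatic nitrogen with ((2-bromophenyl)carbamoyl)methyl gives an at least 16-fold higher number from compound 1 to compound 3 (1.21 log units; beyond the scatter), so compound 1 remains the strongest inhibitor of the three.

The compounds shown leave open whether this step follows from the bromine or from its position, since the substituent and its position change together, and a 4-bromophenyl or 2-methoxyphenyl group on the same amide-type nitrogen would separate the two. From the compounds shown here alone, how an unsubstituted phenyl group there would compare also stays open.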